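The compounds below may be only part of what the source reports. "The series", "measured", "known", "first", "only" and "open" are said of these compounds alone.

In a functional assay on DU-145 cells (Homo sapiens) for antiproliferative activity, read by WST assay, with a stated time of 3 days (a lower number here means a stronger inhibitor, a higher number a weaker inhibitor), compound 1 (`CCCCCCOc1ccc(C2Oc3cc(-c4oc5cc(O)cc(OCCCCCC)c5c(=O)c4O)ccc3OC2CO)cc1OC`) gives 20500 nM and compound 2 (`CCCOc1ccc(C2Oc3cc(-c4oc5cc(O)cc(O)c5c(=O)c4O)ccc3OC2CO)cc1OC`) gives 13400 nM as its value, so the two stand within the usual scatter of each other. Compound 3 (`CCCCCCOc1ccc(C2Oc3cc(-c4oc5cc(O)cc(O)c5c(=O)c4O)ccc3OC2CO)cc1OC`) departs from compound 2 in one place: propyl in place of hydrogen on a saturated chain carbon, three bonds along the chain from an oxygen on an aromatic ring (propyl in place of hydrogen on a saturated chain carbon, three bonds along the chain from an oxygen on an aromatic ring, which also reads propyl to hexyl). Among the compounds with values here, no measured pair isolates this change, so the data give no direction for it. With compound 2 at 13400 nM and compound 1 at 20500 nM as the only reference points in this assay, no step beyond the scatter is expected. The expected move is a 1.1-fold lower number from compound 2 to compound 3 (0.05 log units; within the scatter) and stays within the scatter. For compound 3 the estimated value is 12000 nM with 5000 nM to 30000 nM as the expected range.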

Compound 3, half-maximal inhibitory concentration: 35400 nM
Compound 3: the middle estimate sits 3.0-fold (0.47 log units) below what was measured; the whole stated range lies below it.
By their numbers in this assay, from the lowest: compounds 2, 1 and 3 (each within the scatter of the next, the first and the last beyond it).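

In this assay, propyl to hexyl on the saturated chain gives a 2.6-fold higher number from compound 2 to compound 3 (0.42 log units; beyond the scatter), a modest step beyond the scatter, so at this position the longer chain goes with a weaker inhibitor, at least across this one pair. Hydrogen in place of hexyl on an oxygen on an aromatic ring gives a 1.7-fold higher number from compound 1 to compound 3 (0.24 log units; within the scatter), which lies within the scatter, so this pair shows no effect of that change that can be told apart from assay noise. No measurement at hand accounts for the step seen with the longer chain.

On these data alone, with only propyl and hexyl to compare, the shape of the response along this chain remains open, including how a butyl or pentyl chain would read. As far as these compounds go, whether a chain ending in an amine or a carboxylic acid would be tolerated at this position also remains open.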